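A Chloro Added to the Benzyl Group of Compound 3

A few compounds are considered here, and "the series" means these few. Any claim that something is new, unique, unknown or untested is made for them only; others in the source may bear on it.

Of the compounds shown here, three have been measured in a functional assay on the whole organism (artery, strain albino) with Rattus norvegicus as the target, with a stated time of 240 min, at a dose of 10 mg/kg by the oral route; on this read-out higher numbers stand for more inhibition at the one dose given (going by the name of the read-out) and lower numbers for less inhibition. Compound 1 `COc1ccc(C2N=C(SCc3ccccc3)NC(C)=C2C(=O)Nc2ccc(F)cc2)cc1OC` gives 11.8%. Compound 2 `COc1ccc(C2N=C(SCc3ccc(F)cc3)NC(C)=C2C(=O)Nc2ccc(F)cc2)cc1OC` carries fluoro in place of hydrogen on an aromatic carbon of the benzyl group and gives 28.7%, the step being a number 16.9 percentage points higher from compound 1 to compound 2 (beyond the scatter). Compound 3 `CC1=C(C(=O)Nc2ccc(F)cc2)C(c2ccc([N+](=O)[O-])cc2)N=C(SCc2ccccc2)N1` gives 32.3%, the step being a number 20.5 percentage points higher from compound 1 to compound 3 (beyond the scatter). Compound 3 thus holds the highest of the three numbers, but its gap to compound 2 lies within the scatter, so those two cannot be ordered; only compound 1 sits clearly lower.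

The unmeasured compound 4 `CC1=C(C(=O)Nc2ccc(F)cc2)C(c2ccc([N+](=O)[O-])cc2)N=C(SCc2ccc(Cl)cc2)N1` differs from compound 3 by chloro in place of hydrogen on an aromatic carbon, on an aromatic carbon of the benzyl group, para to a large group. Among the measured compounds shown here, the one measured step that bears on this is a number 16.9 percentage points higher from compound 1 to compound 2 (beyond the scatter), which put fluoro at the same place and raised the number beyond the scatter. Chloro at that place has no measured precedent here, and the nitrophenyl compounds have no second member, so the expectation rests on a single step. A modest rise is therefore expected. Compound 4 is expected to give 43% in this assay, between 26% and 60%. This amounts to an expected step of a number 10.7 percentage points higher from compound 3 to compound 4 (beyond the scatter).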

Compound 4, a percentage reported as inhibition, in the whole organism at one dose (the size of the read-out at that dose, not a potency): 33.3%
Compound 4: the middle estimate sits 9.7 percentage points above what was measured; low and high end bracket the measured number.
By their numbers in this assay, from the lowest: compound 1; then compounds 2, 3 and 4 (each within the scatter of the next).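

In this assay, the change from benzyl to 4-chlorobenzyl on the 4-nitrophenyl compounds comes with a step of a number 1 percentage points higher from compound 3 to compound 4 (within the scatter), so at this place, para to a large group, hydrogen and chloro cannot be told apart in that series. Among the compounds shown here, the only earlier step at this place, a number 16.9 percentage points higher from compound 1 to compound 2 (beyond the scatter), lay beyond the scatter, but it introduced fluoro and belonged to the 3,4-dimethoxyphenyl compounds, so the two steps differ in both the halogen and the group on the saturated ring carbon, and the data cannot separate these two differences. Nothing measured here speaks to the reason for this outcome.

The compounds shown leave open how the 4-fluorobenzyl group would read on the 4-nitrophenyl compounds and how the 4-chlorobenzyl group would read on the 3,4-dimethoxyphenyl compounds, the two pairings that would show whether the halogen or the rest of the molecule sets the size of the step. They also leave open what an amine or a carboxylic acid would do at this same place on the benzyl ring.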